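The source may hold more compounds than are shown below. What is called first, only, known or untested is meant among the compounds shown, and "the series" means these compounds.

Among the compounds with values here, compound 2 `Cc1ccc(OCc2cn(C(c3ccc(C#N)cc3)c3ccc(C#N)cc3)nn2)cc1` gives 11000 nM in an assay on isolated protein for inhibition of Aromatase (Homo sapiens), read by fluorescence and colorimetric assay, with a stated time of 30 min (a lower number here means a stronger inhibitor, a higher number a weaker inhibitor), and the only other number recorded, that of compound 1 `N#Cc1ccc(C(c2ccc(C#N)cc2)n2cc(COc3ccc(Cl)cc3)nn2)cc1` at 16100 nM, lies within the scatter of it, with a 1.5-fold lower number from compound 1 to compound 2 (0.17 log units; within the scatter). Compound 3 `N#Cc1ccc(C(c2ccc(C#N)cc2)n2cc(COc3ccc(-c4ccccc4)cc3)nn2)cc1` differs from compound 2 by phenyl in place of methyl on an aromatic carbon. Within the data shown here, only that single step between compound 1 and compound 2 bears on this change, and it was within the scatter; no measured step touches the phenyl group itself. Compound 3 is therefore expected to stay close to compound 2, with a step of a 1.1-fold higher number from compound 2 to compound 3 (0.04 log units; within the scatter). The estimate for compound 3 in this assay is 12000 nM, within a range from 4000 nM to 40000 nM.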

Compound 3, half-maximal inhibitory concentration: 13400 nM
Beside the measured number, compound 3's estimate is 1.1-fold (0.05 log units) below it; low and high end bracket the measured number.
By their numbers in this assay, from the lowest: compounds 2, 3 and 1 (each within the scatter of the next).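

In this assay, the position para to a large group now carries a phenyl ring of six heavy atoms where methyl has one, and a 1.2-fold higher number from compound 2 to compound 3 (0.09 log units; within the scatter) is matched by a 1.2-fold lower number from compound 1 to compound 3 (0.08 log units; within the scatter) in that neither step leaves the scatter. The earlier pair covered only methyl and chloro, whereas all three groups now give numbers within the scatter of one another. Nothing available accounts for this reading. Open, on these data alone, is whether an amine, a carboxylic acid or a longer chain at this place would give a number beyond the scatter of these three.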